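The source may report more compounds than this note shows. Statements on the series, on what has been measured and on what is new or still open speak of the compounds shown alone.

In a functional assay on MDA-MB-231 cells (Homo sapiens) for antiproliferative activity, read by CCK-8 assay, with a stated time of 72 h (a higher number here means a weaker inhibitor, a lower number a stronger inhibitor), compound 3 `Cc1cc(Nc2cc(N3CCN(C)CC3)nc(Nc3cccc([N+](=O)[O-])c3)n2)n[nH]1` gives 114 nM and compound 2 `Cc1cc(Nc2cc(N3CCN(C)CC3)nc(Nc3ccc(Cl)cc3)n2)n[nH]1` gives 138 nM, a pair within the scatter of each other, with a 1.2-fold lower number from compound 2 to compound 3 (0.08 log units; within the scatter). Compound 1 `Cc1cc(Nc2cc(N3CCN(C)CC3)nc(Nc3ccc(S(N)(=O)=O)cc3)n2)n[nH]1` gives 1210 nM, clearly higher than both. Compound 4 `Cc1cc(Nc2cc(N3CCN(C)CC3)nc(Nc3ccc(C#N)cc3)n2)n[nH]1` is not yet measured and differs from compound 3 as follows: 4-cyanophenyl in place of 3-nitrophenyl on a nitrogen on an aromatic ring. The steps beyond the scatter both leave the 4-sulfamoylphenyl of compound 1: an 8.8-fold lower number from compound 1 to compound 2 (0.94 log units; beyond the scatter) and an 11-fold lower number from compound 1 to compound 3 (1.03 log units; beyond the scatter). Neither involves a nitrile. Going by the values given here, the closest precedent is the exchange between the two other aryl groups, a 1.2-fold lower number from compound 2 to compound 3 (0.08 log units; within the scatter). No step beyond the scatter is therefore expected in this assay. The expected step is a 1.2-fold higher number from compound 3 to compound 4 (0.09 log units; within the scatter). For compound 4 the estimated value is 140 nM, with an expected range of 60 nM to 350 nM.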

Compound 4, half-maximal inhibitory concentration: 75.7 nM
For compound 4 the middle estimate is 1.8-fold (0.27 log units) above the measured one, and the stated range covers the measured number.
By their numbers in this assay, from the lowest: compounds 4, 3 and 2 (each within the scatter of the next); then compound 1.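

On a nitrogen on an aromatic ring, 4-cyanophenyl reads with the 3-nitrophenyl and 4-chlorophenyl groups in this assay: a 1.5-fold lower number from compound 3 to compound 4 (0.18 log units; within the scatter) and a 1.8-fold lower number from compound 2 to compound 4 (0.26 log units; within the scatter) both stay within the scatter, so these three compounds cannot be ordered. Compound 1 remains apart, with a 16-fold lower number from compound 1 to compound 4 (1.20 log units; beyond the scatter), so a nitrile also gives a step beyond the scatter when it replaces sulfamoyl. Nothing available explains these results. Open, as far as these compounds go, is whether a carboxylic acid or a primary amine on this aryl ring would read with compounds 2, 3 and 4 or with compound 1. Also open, from the compounds shown here alone, is whether 3-cyanophenyl would read like 4-cyanophenyl.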